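Urea series: para five-membered heteroaryl swap on the benzyl arm

A few compounds are considered here, and "the series" means these few. Any claim that something is new, unique, unknown or untested is made for them only; others in the source may bear on it.

Measured so far:
compound 1, `Cc1cc(C)c(NC(=O)N(Cc2ccc(-c3nnc(C)o3)cc2)C2CCCCCC2)c(C)c1` — 27 nM
compound 2, `Cc1cc(C)c(NC(=O)N(Cc2cccc(-c3nn[nH]n3)c2)C2CCCCCC2)c(C)c1` — > 1000 nM

In an assay on microsomes from intestine for inhibition of acyl-CoA:cholesterol acyltransferase (Oryctolagus cuniculus) (a lower number here means a stronger inhibitor, a higher number a weaker inhibitor), compound 1 gives 27 nM, the only full number shown for the series. For compound 2 this assay returns only > 1000 nM, which is a limit of the assay and not a number; that is the situation recorded as the limit of > 1000 nM in this assay, at which 1 of the 2 values shown sits. Among the measured compounds shown here, with one number and one limit, no step between measured compounds can be sized, so compound 1 stands alone as the reference point.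

Compound 3, `Cc1cc(C)c(NC(=O)N(Cc2ccc(-n3cncn3)cc2)C2CCCCCC2)c(C)c1`, is not yet measured. It differs from compound 1 by 1H-1,2,4-triazol-1-yl in place of 5-methyl-1,3,4-oxadiazol-2-yl on an aromatic carbon. The five-membered aromatic ring with three hetero atoms is kept, the count of hydrogen-bond acceptors is unchanged, and the group that enters is one heavy atom smaller, with the methyl gone.

Given that compound 1 sits at 27 nM, the step of a 2.2-fold higher number from compound 1 to compound 3 (0.35 log units; beyond the scatter) is expected to be small, at most a modest loss that may not exceed the scatter. Compound 3 is therefore estimated at 60 nM, with a range from 15 nM to 250 nM.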

Compound 3, half-maximal inhibitory concentration: 26 nM
Beside the measured number, compound 3's estimate is 2.3-fold (0.36 log units) above it, within the range that was stated.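

In this assay, the replacement of 5-methyl-1,3,4-oxadiazol-2-yl by 1H-1,2,4-triazol-1-yl on this aromatic carbon, para to a large group, gives a 1.0-fold lower number from compound 1 to compound 3 (0.02 log units; within the scatter), so the two groups cannot be told apart in this read-out. This position therefore accepts more than one five-membered aromatic ring with 3 hetero atoms, and the change of ring atoms together with the loss of the methyl leaves no readable mark on the number. None of the data shown gives a measured property that bears on this result, so the equivalence of the two groups stands here as an observation only.

The methyl and the ring atoms changed together in this step, so the compounds shown leave their separate contributions open, a question that an unsubstituted 1,3,4-oxadiazol-2-yl or a methyl-bearing 1,2,4-triazol-1-yl would address. Also open, as far as these compounds go, is whether the same position would accept a group outside this ring type, such as a carboxylic acid, a dimethylamino group or a six-membered pyridyl ring.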